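The source may report more compounds than this note shows. Statements on the series, on what has been measured and on what is new or still open speak of the compounds shown alone.

Of the compounds shown here, three sharing one core have been measured in an assay for inhibition of Indoleamine 2,3-dioxygenase 1 (Homo sapiens), read by fluorescence, with a stated time of 1 h; on this read-out lower numbers stand for stronger inhibition and higher numbers for weaker inhibition. Compound 1 `NS(=O)(=O)CC(=O)NCCSc1nonc1/C(=N/O)Nc1cccc(C(F)F)c1` gives 130 nM, compound 2 `NS(=O)(=O)CC(=O)NCCSc1nonc1/C(=N/O)Nc1ccc(F)c(Br)c1` gives 71 nM, and compound 3 `N#Cc1cccc(N/C(=N\O)c2nonc2SCCNC(=O)CS(N)(=O)=O)c1` gives 240 nM. Compound 2 shows the lowest number of the three: the step of a 1.8-fold lower number from compound 1 to compound 2 (0.26 log units; within the scatter) lies within the scatter, so compound 1 and compound 2 cannot be told apart, while the step of a 3.4-fold higher number from compound 2 to compound 3 (0.53 log units; beyond the scatter) is a modest, real difference, and the step of a 1.8-fold higher number from compound 1 to compound 3 (0.27 log units; within the scatter) again stays within the scatter.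

Compound 4 `CS(=O)(=O)NCCSc1nonc1/C(=N/O)Nc1ccc(F)c(Br)c1` keeps the aromatic group of compound 2 and changes the chain instead: methylsulfonyl in place of (sulfamoylmethyl)carbonyl on an amine nitrogen. All three measured steps concern the aromatic group on the other side of the core, so none of them bears on this change; how much the chain matters is simply unknown from these numbers. With no guidance, the expectation for compound 4 in this assay is a weak-to-modest loss, with wide uncertainty: an estimated step of a 2.1-fold higher number from compound 2 to compound 4 (0.32 log units; beyond the scatter). Compound 4 is therefore expected to give about 150 nM, most likely between 40 nM and 600 nM.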

Compound 4, half-maximal inhibitory concentration: 270 nM
Estimate against measurement, compound 4: 1.8-fold (0.26 log units) below; the measured number falls inside the stated range.
By their numbers in this assay, from the lowest: compounds 2, 1, 3 and 4 (each within the scatter of the next, the first and the last beyond it).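

The chain on the amine nitrogen matters in this assay: with the 3-bromo-4-fluorophenyl group held fixed, methylsulfonyl in place of (sulfamoylmethyl)carbonyl gives a 3.8-fold higher number from compound 2 to compound 4 (0.58 log units; beyond the scatter), a modest but real weakening of inhibition. Among the compounds shown here, the earlier steps all concerned the aromatic group, so this is the first sign that the other side of the shared core also affects the read-out. The entering group has fewer heavy atoms and no hydrogen-bond donor, and it also lacks the carbonyl of the leaving group, so several features change at once, and nothing measured here says which of them accounts for the step.

The compounds shown leave open which part of (sulfamoylmethyl)carbonyl carries the difference, and an acetyl group or a sulfamoyl group on the same nitrogen would help to separate the carbonyl from the sulfur-containing end. For the compounds shown here, it also remains open whether the same chain change has a similar effect alongside 3-(difluoromethyl)phenyl or 3-cyanophenyl, since this step has been read with only one aromatic group.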